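Replacing sec-butyl with hydroxymethyl at the amide-bearing carbon

This account rests on a few compounds, and the source may have more. Where it says the series, first, only, none or still open, it means among the compounds named here.

Measured so far in a functional assay on the whole organism (Tail, strain ICR) with Mus musculus as the target, in the tail flick test, with a stated time of 30 min, at a dose of 25 umol/kg by the oral route; a lower number here means a weaker effect, a higher number a stronger effect of the compound at the dose given:
- compound 1 `NC(=O)CC[C@H](NC(=O)CN(c1ncnc2c1ncn2C1CCCCO1)C1CC1)C(=O)OCc1ccccc1`: compound 1 gives 47%
- compound 2 `N=C(N)NCCC[C@H](NC(=O)CN(c1nc(Cl)nc2[nH]cnc12)C1CC1)C(=O)O`: compound 2 gives 45.4%
- compound 3 `CC[C@H](C)[C@H](NC(=O)CN(c1ncnc2c1ncn2C1CCCCO1)C1CC1)C(=O)OCc1ccccc1`: compound 3 gives 25.6%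

Compound 3 stands lowest of the three in this assay; compound 2 is the nearest to it and compound 1 the furthest, both beyond the scatter. Compound 4 `O=C(CN(c1ncnc2c1ncn2C1CCCCO1)C1CC1)N[C@@H](CO)C(=O)OCc1ccccc1` differs from compound 3 as follows: hydroxymethyl in place of sec-butyl on a saturated chain carbon bound to an amide-type nitrogen and a carbonyl carbon. For the measured compounds named here, the one step that bears on this place is a number 21.4 percentage points lower from compound 1 to compound 3 (beyond the scatter), where a chain carrying a donor and acceptor gave way to sec-butyl and the read-out fell. The change to compound 4 runs the other way, bringing a donor and acceptor back at the same carbon, so a rise beyond the scatter is expected, though not necessarily to the level of compound 1. Compound 4 is estimated at 40% (range 26% to 54%), an expected step of a number 14.4 percentage points higher from compound 3 to compound 4 (beyond the scatter).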

Compound 4, a percentage reported as activity, at one dose (the size of the read-out at that dose, not a potency): 27.8%
Estimate against measurement, compound 4: 12.2 percentage points above, and the stated range covers the measured number.
By their numbers in this assay, from the lowest: compounds 3 and 4 (each within the scatter of the next); then compounds 2 and 1 (each within the scatter of the next).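

In this assay the exchange of sec-butyl for hydroxymethyl gives a number 2.2 percentage points higher from compound 3 to compound 4 (within the scatter) and so shows that a hydrogen-bond donor and acceptor at this carbon do not by themselves separate these two compounds. Hydroxy in place of carbamoylmethyl gives a number 19.2 percentage points lower from compound 1 to compound 4 (beyond the scatter) and leaves the 2-carbamoylethyl chain of compound 1 standing apart from both other side chains on this shared core. Nothing available here explains this difference. On these data alone, whether the carbamoyl group or the chain length carries the difference stays open. So does whether a primary amine or a longer chain ending in hydroxy at this carbon would reach the level of compound 1.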